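The source may report more compounds than this note shows. Statements on the series, on what has been measured and on what is new or still open speak of the compounds shown alone.

Measured compounds:
- compound 1 `COc1ccc(-c2cc(/C=C/C(=O)c3ccc(N)cc3)[nH]n2)cc1`: 7490 nM
- compound 2 `COc1cc(-c2cc(/C=C/C(=O)c3ccc(N)cc3)[nH]n2)cc(OC)c1OC`: 3920 nM
- compound 3 `COc1ccc(C(=O)/C=C/c2cc(-c3cc(OC)c(OC)c(OC)c3)n[nH]2)cc1OC`: 2770 nM

All three were tested in a functional assay on HOP-62 cells (Homo sapiens) for inhibition, read by sulforhodamine B assay, with a stated time of 48 h; on this read-out higher numbers stand for weaker inhibition of growth and lower numbers for stronger inhibition of growth. On these numbers compound 2 stands second highest of the three; compound 3 lies nearest to it, with a 1.4-fold lower number from compound 2 to compound 3 (0.15 log units; within the scatter), and compound 1 is furthest, its value in this assay lying within the scatter of that of compound 2. The change from compound 2 to compound 4 `COc1ccc(-c2cc(/C=C/C(=O)c3ccc(N)cc3)[nH]n2)cc1OC` is hydrogen in place of methoxy on an aromatic carbon. Going by the values given here, only one step between measured compounds is available, that from compound 2 to compound 3, and it concerns the aryl on the carbonyl carbon, not the aryl that is altered here, so it does not speak directly to this change. Compounds 1 and 2 differ in the same aryl ring, by two methoxy groups rather than one, and their two values in this assay lie within the scatter of each other. Compound 4 sits structurally between them, so in this assay no step beyond the scatter is expected, a 1.4-fold higher number from compound 2 to compound 4 (0.15 log units; within the scatter). For compound 4 the estimate in this assay is 5500 nM, with a range from 2500 nM to 12000 nM, because compound 2 gave 3920 nM and compound 1 gave 7490 nM.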

Compound 4, concentration for total growth inhibition: 9670 nM
Estimate against measurement, compound 4: 1.8-fold (0.25 log units) below, within the range that was stated.
By their numbers in this assay, from the lowest: compounds 3, 2, 1 and 4 (each within the scatter of the next, the first and the last beyond it).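

In this assay, going by these compounds alone, the single change of methoxy to hydrogen on this aromatic carbon is the first one-place change on this ring that goes beyond the scatter (a 2.5-fold higher number from compound 2 to compound 4 (0.39 log units; beyond the scatter)), so compound 4 inhibits growth modestly less strongly than compound 2. The methoxy that differs between compound 1 and compound 4 shows no such effect (a 1.3-fold higher number from compound 1 to compound 4 (0.11 log units; within the scatter)), so on these numbers the two methoxy positions on this ring do not count equally. Nothing measured here explains why this methoxy matters.

On these data alone, what remains open is whether a hydroxyl group, a fluorine atom or a longer ethoxy chain on this carbon would serve as well as methoxy. Also open, as far as these compounds go, is whether the same step would appear with the 3,4-dimethoxyphenyl on the carbonyl carbon, as in compound 3.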